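A few compounds are considered here, and "the series" means these few. Any claim that something is new, unique, unknown or untested is made for them only; others in the source may bear on it.

Measured in a functional assay on BGC-823 cells (Homo sapiens) for inhibition, read by MTT assay, with a stated time of 72 h; a higher number here means a weaker inhibitor, a lower number a stronger inhibitor
- compound 1 `Cc1cc(N2CC[C@@H](C)[C@@H](N(C)c3ncnc4[nH]ccc34)C2)n2nc(SCc3ccccc3Br)nc2n1` gives 81100 nM
- compound 2 `Cc1cc(N2CC[C@@H](C)[C@@H](N(C)c3ncnc4[nH]ccc34)C2)n2nc(SCc3csc4ccc(Cl)cc34)nc2n1` gives > 100000 nM (a limit of the assay, not a number)
- compound 3 `Cc1cc(N2CC[C@@H](C)[C@@H](N(C)c3ncnc4[nH]ccc34)C2)n2nc(SCC3CCCCC3)nc2n1` gives 16300 nM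

Compound 3 has the lower of the two actual numbers, with compound 1 nearest. Compound 4 `COc1ccc(CSc2nc3nc(C)cc(N4CC[C@@H](C)[C@@H](N(C)c5ncnc6[nH]ccc56)C4)n3n2)cc1` has 4-methoxyphenyl in place of cyclohexyl on a saturated chain carbon bound to a sulfur. Two measured steps bring in cyclohexyl: a 5.0-fold lower number from compound 1 to compound 3 (0.70 log units; beyond the scatter) and an at least 6.1-fold lower number from compound 2 to compound 3 (0.78 log units; beyond the scatter), both beyond the scatter. Compound 4 reverses that kind of change and carries a phenyl group, as does compound 1 at 81100 nM, so a weaker result is expected. The expected change is a 3.1-fold higher number from compound 3 to compound 4 (0.49 log units; beyond the scatter) in this assay, a modest rise. For compound 4 the estimated value is 50000 nM (range 18000 nM to 100000 nM).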

Compound 4, half-maximal inhibitory concentration: 69900 nM
Estimate against measurement, compound 4: 1.4-fold (0.15 log units) below; low and high end bracket the measured number.
By their numbers in this assay, from the lowest: compound 3; then compounds 4 and 1 (each within the scatter of the next). At a limit, above all of these: compound 2.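

In this assay, cyclohexyl now also keeps its lead over a second phenyl group: the change to 4-methoxyphenyl brings a 4.3-fold higher number from compound 3 to compound 4 (0.63 log units; beyond the scatter). The two different phenyl groups cannot be told apart: 4-methoxyphenyl in place of 2-bromophenyl gives a 1.2-fold lower number from compound 1 to compound 4 (0.06 log units; within the scatter). Putting 4-methoxyphenyl in place of 5-chloro-1-benzothiophen-3-yl brings an at least 1.4-fold lower number from compound 2 to compound 4 (0.15 log units; that floor lies within the scatter) and this is only a floor, because it rests on a limit of the assay and not on a number: the limit of > 100000 nM in this assay, at which 1 of the 4 values shown sits.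

Cyclohexyl is the only saturated ring shown at this position. On these data alone, whether a cyclopentyl ring, a straight hexyl chain or a piperidine ring with its amine would keep the lower number stays open.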